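A few compounds are considered here, and "the series" means these few. Any claim that something is new, unique, unknown or untested is made for them only; others in the source may bear on it.

Measured in a functional assay on NCI-H727 cells (Homo sapiens) for antiproliferative activity, with a stated time of 48 h (a higher number here means a weaker inhibitor, a lower number a stronger inhibitor), so far:
- compound 1 `CC(=O)c1ccc(-c2ccc(N3CCCC3)nn2)cc1` gives > 25000 nM as a limit
- compound 2 `COc1ccc(Nc2ccc(-c3ccccc3)nn2)cc1` gives > 25000 nM as a limit
- compound 3 `CCN(CC)c1ccc(-c2cccc(Cl)c2)nn1` gives > 25000 nM as a limit

None of these three results is a true number, since each one is only a limit. The record for this assay is flat, with the limit of > 25000 nM in this assay, at which 3 of the 3 values shown sit, as its whole content. Compound 3 therefore stands at > 25000 nM and this is a limit.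

Compound 4 `CCOC(=O)c1cccc(-c2ccc(N(CC)CC)nn2)c1` carries ethoxycarbonyl in place of chloro on an aromatic carbon, meta to a large group ethoxycarbonyl in place of chloro on an aromatic carbon and the rest of the structure stays the same. For the measured compounds named here, no two measured compounds differ in one place only, so no measured step guides this change. Compound 1 also holds a carbonyl and gives > 25000 nM as a limit. No step beyond the scatter is expected in this assay and another limit is the likeliest result. The estimated step of a number no higher from compound 3 to compound 4 (the limit leaves the size open) is expected to stay within the scatter. Compound 4 is expected near 25000 nM in an estimated range from 12000 nM to 50000 nM as its likely span.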

Compound 4, half-maximal inhibitory concentration: 30000 nM
Estimate against measurement, compound 4: 1.2-fold (0.08 log units) below; the range from low to high includes it.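

Compound 3 is recorded only as a limit, so no new step can be read between it and compound 4. The compounds shown leave open which change to the shared core, if any, would give a clearly stronger inhibitor in this assay, with most results resting at one limit: the limit of > 25000 nM in this assay, at which 3 of the 4 values shown sit.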